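Swapping the Thiophene on the Cyclopropane for a Methylthiazole

The compounds below may be only part of what the source reports. "The series", "measured", "known", "first", "only" and "open" are said of these compounds alone.

Of the compounds shown here, three sharing one core have been tested in a functional assay for agonist activity at G protein-coupled receptor 88 (Homo sapiens), read by HTRF and cAMP accumulation; on this read-out higher numbers stand for an effect only at larger amounts of compound and lower numbers for an effect already at smaller amounts. Compound 1 `CC[C@H](C)[C@H](N)CN(C(=O)[C@@H]1C[C@H]1c1ccccc1Cl)c1ccc(-c2ccccc2)cc1` carries a 2-chlorophenyl on a saturated ring carbon of the cyclopropane; in this assay compound 1 reaches only the limit of > 25000 nM, a limit rather than a number. Compound 2 `CC[C@H](C)[C@H](N)CN(C(=O)[C@@H]1C[C@H]1c1ccc(F)c(F)c1)c1ccc(-c2ccccc2)cc1` carries a 3,4-difluorophenyl there, and in this assay compound 2 gives 720 nM. Compound 3 `CC[C@H](C)[C@H](N)CN(C(=O)[C@@H]1C[C@H]1c1ccsc1)c1ccc(-c2ccccc2)cc1` carries a thiophen-3-yl, and in this assay compound 3 gives 450 nM. The step of an at least 34-fold lower number from compound 1 to compound 2 (1.54 log units; beyond the scatter) and the step of an at least 55-fold lower number from compound 1 to compound 3 (1.74 log units; beyond the scatter) are both large, while the step of a 1.6-fold lower number from compound 2 to compound 3 (0.20 log units; within the scatter) stays within the scatter. Compound 3 thus holds the lower of the two numbers reported, but compound 2 sits close enough that no order between them can be claimed.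

Compound 4 `CC[C@H](C)[C@H](N)CN(C(=O)[C@@H]1C[C@H]1c1nc(C)cs1)c1ccc(-c2ccccc2)cc1` is not yet measured. It differs from compound 3 by 4-methyl-1,3-thiazol-2-yl in place of thiophen-3-yl on a saturated ring carbon. Among the compounds with values here, the only step that bears directly on a swap between two small aromatic groups at this position is the one from compound 2 to compound 3, which was within the scatter. A change within the scatter is therefore expected, a 1.4-fold higher number from compound 3 to compound 4 (0.16 log units; within the scatter), with compound 4 estimated at 650 nM in this assay, between 220 nM and 2000 nM.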

Compound 4, half-maximal effective concentration: 730 nM
For compound 4 the middle estimate is 1.1-fold (0.05 log units) below the measured one; the measured number falls inside the stated range.
By their numbers in this assay, from the lowest: compounds 3, 2 and 4 (each within the scatter of the next). At a limit, above all of these: compound 1.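

In this assay, the step of a 1.6-fold higher number from compound 3 to compound 4 (0.21 log units; within the scatter) shows that this saturated ring carbon takes a five-membered aromatic ring with 2 hetero atoms and a methyl group as readily as one with 1 hetero atom, since the entering 4-methyl-1,3-thiazol-2-yl cannot be told apart from the leaving thiophen-3-yl. The step of a 1.0-fold higher number from compound 2 to compound 4 (0.01 log units; within the scatter) adds that the same holds against the six-membered 3,4-difluorophenyl, so compounds 2, 3 and 4 now form a group of three different aromatic rings whose numbers lie within the scatter of one another, with compound 1 as the one compound shown that goes against this pattern. The step of an at least 34-fold lower number from compound 1 to compound 4 (1.53 log units; beyond the scatter) is large, yet its full size stays unknown, as compound 1 stands at a limit and not at a number: the limit of > 25000 nM in this assay, at which 1 of the 4 values shown sits.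

On these data alone, compound 4 brings in the ring nitrogen and the methyl group together, so the share of each stays open; a plain 1,3-thiazol-2-yl would separate them. Also open, as far as these compounds go, is how an amine, a carboxylic acid or a longer chain on this ring carbon would read in this assay.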